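This account rests on a few compounds, and the source may have more. Where it says the series, first, only, none or still open, it means among the compounds named here.

Compound 1 `COc1cc(C=C(C(=O)/C=C/c2ccc(OC)c(OC)c2)C(=O)/C=C/c2ccc(OC)c(OC)c2)ccc1O`: 530 nM
Compound 2 `COc1ccc(/C=C/C(=O)C(=Cc2cccc(F)c2)C(=O)/C=C/c2ccc(OC)c(OC)c2)cc1OC`: 580 nM
Compound 3 `COc1ccc(/C=C/C(=O)C(=Cc2ccc(F)cc2)C(=O)/C=C/c2ccc(OC)c(OC)c2)cc1OC`: 550 nM

All three values come from a functional assay on A549 cells (Homo sapiens) for inhibition, read by sulforhodamine B assay, with a stated time of 48 h; a lower number here means a stronger inhibitor of growth, a higher number a weaker inhibitor of growth. They lie within the scatter of one another, so compound 3 stands level with compounds 1 and 2.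

Compound 4 `COc1ccc(/C=C/C(=O)C(=Cc2ccc(O)cc2)C(=O)/C=C/c2ccc(OC)c(OC)c2)cc1OC` is not yet measured. It differs from compound 3 in one place, with hydroxy in place of fluoro on an aromatic carbon.

The closest evidence is the swap of 4-hydroxy-3-methoxyphenyl for 4-fluorophenyl, a 1.0-fold higher number from compound 1 to compound 3 (0.02 log units; within the scatter). This step is within the scatter, and it shows that a group carrying hydroxy and a group carrying fluoro can give matching values. Moving the fluoro, a 1.1-fold lower number from compound 2 to compound 3 (0.02 log units; within the scatter), also stays within the scatter. Within the data shown here, no measured compound carries 4-hydroxyphenyl itself, so this evidence is indirect.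

No step beyond the scatter is therefore expected in this assay, and the estimated change is a 1.1-fold lower number from compound 3 to compound 4 (0.02 log units; within the scatter). The estimate for compound 4 is 520 nM, with an expected range of 250 nM to 1100 nM.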

Compound 4, concentration for 50% growth inhibition: 420 nM
Compound 4: the middle estimate sits 1.2-fold (0.09 log units) above what was measured, within the range that was stated.
By their numbers in this assay, from the lowest: compounds 4, 1, 3 and 2 (each within the scatter of the next).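

In this assay, among these compounds, this is the first direct exchange of fluoro for hydroxy on this aromatic carbon, para to a large group, and it gives a step within the scatter (a 1.3-fold lower number from compound 3 to compound 4 (0.12 log units; within the scatter)). So a hydroxy, which counts as a hydrogen-bond donor and acceptor, and a fluoro, which counts as neither, give matching values here. The same holds against the 3-fluorophenyl compound (a 1.4-fold lower number from compound 2 to compound 4 (0.14 log units; within the scatter)) and when hydrogen replaces the methoxy of the 4-hydroxy-3-methoxyphenyl group (a 1.3-fold lower number from compound 1 to compound 4 (0.10 log units; within the scatter)), and no supporting measurement is available to explain these matching values.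

The compounds shown leave open whether an amine or a carboxylic acid on this carbon would move the number beyond the scatter. They also leave open what an ethoxy or a longer chain would do there.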